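Methylsulfanyl replaced by a selenium-bearing group: working notes

The source may report more compounds than this note shows. Statements on the series, on what has been measured and on what is new or still open speak of the compounds shown alone.

Measured in an ADME assay on MCF-10A cells (Homo sapiens) for cytotoxicity, read by MTT assay, with a stated time of 72 h; a higher number here means a weaker inhibitor of growth, a lower number a stronger inhibitor of growth:
compound 1 `CS/C(=N\C(=O)c1ccno1)NC(=O)c1ccno1` gives 16900 nM;
compound 2 `CS/C(=N\C(=O)c1ccco1)NC(=O)c1ccco1` gives 8220 nM;
compound 3 `O=C(/N=C(/NC(=O)c1ccno1)[Se]Cc1ccccc1)c1ccno1` gives 7800 nM.

Compounds 1 and 3 share a core and differ in one place: a group of 8 heavy atoms (7 carbon, 1 selenium; one six-membered aromatic ring of carbon only) in place of a group of 2 heavy atoms (1 carbon, 1 sulfur; no ring), on a carbon with a double bond to nitrogen. This change gave a 2.2-fold lower number from compound 1 to compound 3 (0.34 log units; beyond the scatter). Compound 2 carries a different core; how the core of compound 2 differs from the core of compound 1 is not broken down here. Compound 4 `O=C(/N=C(/NC(=O)c1ccco1)[Se]Cc1ccccc1)c1ccco1` is not yet measured in this assay. It stands to compound 2 as compound 3 stands to compound 1: a group of 8 heavy atoms (7 carbon, 1 selenium; one six-membered aromatic ring of carbon only) in place of a group of 2 heavy atoms (1 carbon, 1 sulfur; no ring), on a carbon with a double bond to nitrogen. The two changes sit on the same kind of carbon with the same neighbours, so this is the same change, made on a second core.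

Among the measured compounds shown here, with only one measured instance of the change, the expectation for compound 4 rests on it alone. The step from compound 2 to compound 4 in this assay is expected to be a 2.2-fold lower number from compound 2 to compound 4 (0.35 log units; beyond the scatter), of about the size seen in a 2.2-fold lower number from compound 1 to compound 3 (0.34 log units; beyond the scatter), with wider uncertainty because the core of compound 2 has not been tested with this change. Compound 4 is therefore estimated at 3700 nM, most likely between 1500 nM and 9000 nM.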

Compound 4, concentration for 50% growth inhibition: 8800 nM
For compound 4 the middle estimate is 2.4-fold (0.38 log units) below the measured one, within the range that was stated.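

In this assay the change gave a 1.1-fold higher number from compound 2 to compound 4 (0.03 log units; within the scatter), so on the core of compound 2 the swap of methylsulfanyl for the selenium-bearing group produced no step beyond the scatter. Set against the earlier step, the two results cannot be told apart: the same change on two cores in this assay, a 2.2-fold lower number (0.34 log units; beyond the scatter) from compound 1 to compound 3 and a 1.1-fold higher number (0.03 log units; within the scatter) from compound 2 to compound 4, 2.3-fold (0.37 log units) apart, within the scatter of two such steps This shows no measurable disagreement between the two cores, but with only two pairs in one assay it does not show that the modest step seen on the core of compound 1 carries over, nor that it is lost on the core of compound 2.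

The change alters the atom and the attached group together, so the compounds shown leave open how much each part contributes to the step on the core of compound 1. A methyl group on selenium, or the same six-membered aromatic ring carried through sulfur, would separate the two, and an amine on that carbon remains an open comparison.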